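Aromatic fluoro removal on the difluoro acrylamide core

This account rests on a few compounds, and the source may have more. Where it says the series, first, only, none or still open, it means among the compounds named here.

Measured so far:
compound 1 `NC(=O)/C=C1\CCc2c(F)cc(F)cc21` gives 69 mg/kg in a functional assay on the whole organism with Mus musculus as the target; on this read-out lower numbers stand for an effect already at smaller amounts and higher numbers for an effect only at larger amounts of compound;
compound 2 `O=C(/C=C1\CCc2c(F)cc(F)cc21)NCCO` gives 100 mg/kg;
compound 3 `CN(C)C(=O)/C=C1\CCc2c(F)cc(F)cc21` gives 50 mg/kg.

Compound 1 stands second highest of the three numbers; its nearest neighbour is compound 3 (a 1.4-fold lower number from compound 1 to compound 3 (0.14 log units; within the scatter)) and its furthest is compound 2 (a 1.4-fold higher number from compound 1 to compound 2 (0.16 log units; within the scatter)). The third step, a 2.0-fold lower number from compound 2 to compound 3 (0.30 log units; within the scatter), is also within the scatter, so across the three amide variants the read-out is flat.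

Compound 4 `NC(=O)/C=C1\CCc2ccc(F)cc21` differs from compound 1 by hydrogen in place of fluoro on an aromatic carbon. Within the data shown here, all three measured steps change the amide end of the molecule; none touches the aromatic ring, so no measured step bears directly on this change. Among the measured compounds shown here, the only guidance is that the series so far has tolerated single-site changes without a step beyond the scatter. The expectation for compound 4 is therefore no step beyond the scatter, a 1.0-fold higher number from compound 1 to compound 4 (0.01 log units; within the scatter). Compound 4 is estimated at 70 mg/kg, with a range from 35 mg/kg to 140 mg/kg.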

Compound 4, dose for half-maximal effect: 56 mg/kg
Compound 4: middle estimate off by 1.3-fold (0.10 log units), on the high side, within the range that was stated.
By their numbers in this assay, from the lowest: compounds 3, 4, 1 and 2 (each within the scatter of the next).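

Among these compounds, this is the first step on the aromatic ring rather than at the amide end of the series: in this assay, hydrogen in place of fluoro on the aromatic carbon ortho to a fused ring gives a 1.2-fold lower number from compound 1 to compound 4 (0.09 log units; within the scatter) and so stays within the scatter. With the amide end of compound 1 kept, the read-out therefore does not depend on a fluoro group at this place, and this ring change is as flat as the amide changes. No measurement at hand accounts for this result.

The compounds shown leave open whether the remaining fluoro group can also give way to hydrogen, and whether a chloro, methoxy or amino group at the vacated carbon would stay within the scatter. Also open, as far as these compounds go, is whether the same change holds with the dimethylamino amide of compound 3 or the 2-hydroxyethyl amide of compound 2.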